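The compounds below may be only part of what the source reports. "The series", "measured", "known", "first", "only" and "open" are said of these compounds alone.

Measured so far:
compound 1 `CCc1cc(C(C)=O)c(O)cc1OCCCC(C)(C)C(=O)O` — 43%
compound 2 `C=CCc1cc(C(C)=O)c(O)cc1OCCCCC` — 23%
compound 3 `C=CCc1cc(C(C)=O)c(O)cc1OCCCCO` — 9%

In an assay on isolated protein for binding affinity to leukotriene B4 receptor 1 (Homo sapiens), tested at 1 uM (a higher number here means more inhibition at the concentration tested (going by the name of the read-out), a lower number less inhibition), compound 1 gives the highest of the three numbers, its nearest neighbour compound 2 standing lower and compound 3 lower still. Compound 4 `CCc1cc(C(C)=O)c(O)cc1OCCCCc1nnn[nH]1` differs from compound 1 in one place: (1H-tetrazol-5-yl)methyl in place of 1-carboxy-1-methylethyl on a saturated chain carbon, three bonds along the chain from an oxygen on an aromatic ring. For the measured compounds named here, the only measured step, a number 14 percentage points lower from compound 2 to compound 3 (beyond the scatter), concerns a hydroxy in place of a methyl at the chain end and so says nothing direct about exchanging an acid-bearing group for a tetrazole-bearing one; no measured pair bears on this change. Compound 4 is therefore expected to stay close to compound 1, with a number 3 percentage points lower from compound 1 to compound 4 (within the scatter), an estimate of 40% spanning 15% to 65%.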

Compound 4, a percentage reported as inhibition, at one concentration (the size of the read-out at that concentration, not a potency): 19%
Beside the measured number, compound 4's estimate is 21 percentage points above it; measured number inside the range.
By their numbers in this assay, from the lowest: compounds 3, 4 and 2 (each within the scatter of the next, the first and the last beyond it); then compound 1.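

In this assay, putting (1H-tetrazol-5-yl)methyl in place of 1-carboxy-1-methylethyl, on a saturated chain carbon three bonds along the chain from an oxygen on an aromatic ring, gives a number 24 percentage points lower from compound 1 to compound 4 (beyond the scatter). The two groups hold the same count of heavy atoms, so this position responds to the kind of group and not only to its count of heavy atoms. No measurement at hand explains the drop.

Still open, from the compounds shown here alone, is how a plain unbranched carboxylic acid would read at the chain end. Going by these compounds, a shorter or longer chain carrying the tetrazole is equally open.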